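Isopentyl for phenyl on the ring amide nitrogen

A few compounds are considered here, and "the series" means these few. Any claim that something is new, unique, unknown or untested is made for them only; others in the source may bear on it.

Compound 3, `CS(=O)(=O)Nc1ccc2c(c1)S(=O)(=O)N=C(C1=C(O)C3CCCC3N(c3ccccc3)C1=O)N2`, belongs to a small set of three close relatives tested in an ADME assay on Huh-7 cells (Homo sapiens) for cytotoxicity, with a stated time of 72 h; a lower number here means that less compound is tolerated, a higher number that more compound is tolerated. For compound 3 itself, this assay gave "not determined" (no result reported). Compound 1, `CN1C(=O)C(C2=NS(=O)(=O)c3cc(NS(C)(=O)=O)ccc3N2)=C(O)C2CCCC21`, likewise gives "not determined" (no result reported) in this assay. Compound 2, `CS(=O)(=O)Nc1ccc2c(c1)S(=O)(=O)N=C(C1=C(O)C3CCCC3N(Cc3ccc(F)cn3)C1=O)N2`, reaches only the limit of the assay, > 33000 nM, which is not a number. So there is the limit of > 33000 nM in this assay, at which 1 of the 3 values shown sits, while the other two entries carry no number at all. Compound 4, `CC(C)CCN1C(=O)C(C2=NS(=O)(=O)c3cc(NS(C)(=O)=O)ccc3N2)=C(O)C2CCCC21`, is the next relative: compared with compound 3 it carries isopentyl in place of phenyl on an amide-type nitrogen in a ring. No measured step between any two of these compounds exists, so no size or direction can be read for this change. Going by the values given here, from the single value shown, compound 4 is expected to also be tolerated up to the limit, giving an estimated 33000 nM with a range of 12000 nM to 100000 nM.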

Compound 4, half-maximal cytotoxic concentration: > 1000 nM
Compound 4: only a limit was reported; the forecaster's own chance of this, stated with the estimate: 75%; the middle value lies beyond the limit too.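

No new step can be read: compound 2 and compound 4 each give only a limit, not a number. What the compounds shown leave open is whether the group on the ring amide nitrogen changes the result in this assay.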